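Pyrrolidin-1-yl to 1H-imidazol-1-yl in the series

This account rests on a few compounds, and the source may have more. Where it says the series, first, only, none or still open, it means among the compounds named here.

Measured so far in a functional assay on the whole organism for agonist activity, with Mus musculus as the target (on this read-out higher numbers stand for an effect only at larger amounts of compound and lower numbers for an effect already at smaller amounts), as the read-out:

- compound 1 `COC(=O)N(C)C(C)C#CCn1ccnc1` gives 8 mg/kg
- compound 2 `CN1CCN(CC#CCn2ccnc2)C1=O` gives 1.4 mg/kg
- compound 3 `CC(C#CCN1CCCC1)N1CCN(C)C1=O` gives > 30 mg/kg as a limit

Compound 3 stands at the limit of > 30 mg/kg in this assay, at which 1 of the 3 values shown sits, and this is a limit of the assay and not a number. The next compound is compound 4 `CC(C#CCn1ccnc1)N1CCN(C)C1=O` and the change from compound 3 is 1H-imidazol-1-yl in place of pyrrolidin-1-yl on a saturated chain carbon bound to a triple-bonded carbon on a saturated chain carbon bound to a triple-bonded carbon.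

Among the compounds with values here, no step between measured compounds that differ in one place is available, so any expectation rests on the values alone. Compound 1 carries 1H-imidazol-1-yl and gives 8 mg/kg as a number. Compound 2 also carries 1H-imidazol-1-yl and gives 1.4 mg/kg as a number. Compound 3 carries pyrrolidin-1-yl instead, and with so few compounds this remains a weak basis.

In this assay the expected change is an at least 6.0-fold lower number from compound 3 to compound 4 (0.77 log units; beyond the scatter) toward lower numbers and beyond the scatter. For compound 4 the estimated value is 5 mg/kg with an expected range from 1.5 mg/kg to 18 mg/kg on the same read-out.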

Compound 4, dose for half-maximal effect: > 100 mg/kg
Compound 4 ended at the assay's limit; the forecaster's own chance of this, stated with the estimate: 10%; middle value at least 20-fold (1.30 log units) from the limit.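

In this assay compound 4 gives no number, only a limit of the assay: the limit of > 100 mg/kg in this assay, at which 1 of the 4 values shown sits.

Compound 3 likewise gives only a limit of the assay: the limit of > 30 mg/kg in this assay, at which 1 of the 4 values shown sits.

Within the data shown here, the exchange of pyrrolidin-1-yl for 1H-imidazol-1-yl therefore cannot be read, but methyl in place of hydrogen on a saturated chain carbon bound to an amide-type nitrogen in a ring and a triple-bonded carbon gives the first readable single change, an at least 71-fold higher number from compound 2 to compound 4 (1.85 log units; beyond the scatter), showing that with 1H-imidazol-1-yl present in both compounds, this one carbon still separates a low number from a limit.

Still open, going by these compounds, is how the read-out responds to other groups on this saturated chain carbon, such as ethyl, hydroxymethyl or a second methyl, and whether the two mirror-image forms of compound 4 behave alike. Also open, on these data alone, is whether a dimethylamino group in place of 1H-imidazol-1-yl would bring the methyl-bearing compounds back to a measurable number in this assay.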